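Fluorine on the Core: From Compound 1 to Compound 4

This account rests on a few compounds, and the source may have more. Where it says the series, first, only, none or still open, it means among the compounds named here.

Of the compounds shown here, three sharing a common core have been measured in an assay on IMR-32 cells for displacement of a labelled ligand from corticotropin-releasing factor receptor 1 (Homo sapiens), read by scintillation counting, with a stated time of 2 h; a higher number here means a weaker inhibitor, a lower number a stronger inhibitor. Compound 1 `CCc1nc(NC(CC)CC)cnc1-c1ccc(Cl)cc1Cl` gives 545 nM, the highest of the three numbers. Compound 2 `CCC(CC)Nc1nc(C)c(-c2ccc(Cl)cc2Cl)nc1C` gives 27 nM, and compound 3 `CCc1nc(-c2ccc(Cl)cc2Cl)c(CC)nc1CC(CC)CC` gives 68 nM. Compound 1 therefore stands at the weak end of this small set: its number lies above that of compound 3 and further still above that of compound 2, both gaps being beyond the scatter of repeated measurements.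

Compound 4 `CCc1nc(NC(CC)CC)c(F)nc1-c1ccc(Cl)cc1Cl` has not yet been measured in this assay. It differs from compound 1 in one place: fluoro in place of hydrogen on an aromatic carbon. For the measured compounds named here, no pair of measured compounds shows this exact change, so the size of the step is uncertain. The only hint comes from the measured set itself, where compound 2, which carries a substituent in place of the hydrogen on that ring carbon, gives 27 nM against 545 nM for compound 1. On that basis a modest gain, rather than none, is expected.

Compound 4 is estimated to give 200 nM in this assay, with a likely range from 60 nM to 700 nM. The expected step of a 2.7-fold lower number from compound 1 to compound 4 (0.44 log units; beyond the scatter) is a moderate one toward a lower number.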

Compound 4, inhibition constant: 167 nM
Compound 4: middle estimate off by 1.2-fold (0.08 log units), on the high side; measured number inside the range.
By their numbers in this assay, from the lowest: compound 2; then compound 3; then compound 4; then compound 1.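

Fluoro in place of hydrogen on this aromatic carbon, next to the ring nitrogen and ortho to the (pentan-3-yl)amino group, is the first change in the set that can be read on its own: in this assay it gives a 3.3-fold lower number from compound 1 to compound 4 (0.51 log units; beyond the scatter). Before this, no measured pair differed in one place only, so nothing showed what this ring carbon contributes apart from the other substituents on the shared core. The result shows that a single fluorine atom at this carbon is enough to move the number modestly but beyond the scatter, although no measurement here accounts for the direction or size of that step.

With only one substituent tested at this carbon, the compounds shown leave open whether a similar step would follow from chloro, methyl, methoxy or a nitrile in the same place. They also leave open whether the fluoro step would hold if the (pentan-3-yl)amino group gave way to a longer chain or a cyclic amine, or if the ethyl group gave way to methyl.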